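The compounds below may be only part of what the source reports. "The series", "measured", "known", "first", "only" and "open" are said of these compounds alone.

In an ADME assay on MRC5 cells (Homo sapiens) for cytotoxicity, read by MTT assay, with a stated time of 24 h (a higher number here means that more compound is tolerated, a lower number that less compound is tolerated), compound 2 `CC1(C)[C@H]2CC[C@]1(C)N(Cc1cn(-c3ccccc3)nn1)C(=O)C2` gives 9730 nM and compound 1 `CC1(C)[C@H]2CC[C@]1(C)N(Cc1cn(-c3cccc(Cl)c3)nn1)C(=O)C2` gives 8840 nM. For the measured compounds named here, these are the only two measured values, and they lie within the scatter of each other, so compound 2 stands level with its one neighbour.

Compound 3 `CC1(C)[C@H]2CC[C@]1(C)N(Cc1cn(-c3cccc(Br)c3)nn1)C(=O)C2` has not yet been measured. It differs from compound 2 by bromo in place of hydrogen on an aromatic carbon, meta to a large group, turning phenyl into 3-bromophenyl. Going by the values given here, no compound carrying bromo has been measured, so the evidence is indirect. Among the compounds with values here, one measured step bears on the change, the exchange of chloro for hydrogen on an aromatic carbon, and it is small: a 1.1-fold higher number from compound 1 to compound 2 (0.04 log units; within the scatter). Read in reverse, this step adds a single group to the ring of compound 2, as the new change does. On that basis, no step beyond the scatter is expected in this assay. The expected step is a 1.1-fold lower number from compound 2 to compound 3 (0.04 log units; within the scatter), which is an estimate only. For compound 3 the estimated value is 8800 nM, with an expected range of 5500 nM to 14000 nM.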

Compound 3, half-maximal cytotoxic concentration: 38800 nM
Beside the measured number, compound 3's estimate is 4.4-fold (0.64 log units) below it; the whole stated range lies below it.
By their numbers in this assay, from the lowest: compounds 1 and 2 (each within the scatter of the next); then compound 3.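

For the compounds shown here, on the aromatic carbon meta to a large group, the earlier compounds suggested that a substituent made little difference in this assay, but bromo in place of hydrogen gives a 4.0-fold higher number from compound 2 to compound 3 (0.60 log units; beyond the scatter) and so shows that this place does respond to what it carries. Bromo in place of chloro at the same carbon gives a 4.4-fold higher number from compound 1 to compound 3 (0.64 log units; beyond the scatter) and a step of similar size, so among these compounds the outcome depends on which group is present and not simply on whether the hydrogen has been replaced; compound 1, with chloro, goes against any reading in which every added halogen raises the number. Nothing in the data shown accounts for this difference between bromo and chloro.

As far as these compounds go, whether iodo would carry the trend further, or whether a methyl, a methoxy or an amine at this carbon would behave like bromo or like chloro, remains open. The compounds shown also carry bromo at this one place only, so they leave open whether bromo elsewhere on the phenyl ring would give a comparable number in this assay.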